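Cyclohexyl to Benzyl on the Carbamate Nitrogen

The source may report more compounds than this note shows. Statements on the series, on what has been measured and on what is new or still open speak of the compounds shown alone.

Two compounds of this series share one core and differ only in the group on the carbamate nitrogen. Compound 1 `O=C(NC1CCCC1)Oc1cccc(C(=O)c2nc3ccccc3o2)c1` carries a cyclopentyl group, and in an assay (strain Wistar) for inhibition of Fatty-acid amide hydrolase 1 (Rattus norvegicus) (on this read-out lower numbers stand for stronger inhibition and higher numbers for weaker inhibition), compound 1 gives 28 nM. Compound 2 `O=C(NC1CCCCC1)Oc1cccc(C(=O)c2nc3ccccc3o2)c1` carries a cyclohexyl group, and in this assay compound 2 gives 47 nM. Among the compounds with values here, the single measured step, a 1.7-fold higher number from compound 1 to compound 2 (0.22 log units; within the scatter), is too small to be read as a real change. Within the data shown here, on the numbers at hand compound 2 stands at the top of the two, with compound 1 as its only neighbour and within the scatter of it.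

Compound 3 `O=C(NCc1ccccc1)Oc1cccc(C(=O)c2nc3ccccc3o2)c1` is the next step from compound 2: benzyl in place of cyclohexyl on an amide-type nitrogen. Among the measured compounds shown here, the one measured step bears on it only loosely, since it shows that exchanging cyclopentyl for cyclohexyl left the number within the scatter. Benzyl brings an aromatic ring in place of a non-aromatic one, so a larger move is possible, yet no measured step points in either direction. Compound 3 is therefore expected to show a step of a 1.3-fold higher number from compound 2 to compound 3 (0.11 log units; within the scatter), not beyond the scatter. The estimate for compound 3 in this assay is 60 nM, with a range from 15 nM to 250 nM.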

Compound 3, half-maximal inhibitory concentration: 152 nM
Estimate against measurement, compound 3: 2.5-fold (0.40 log units) below; measured number inside the range.
By their numbers in this assay, from the lowest: compounds 1 and 2 (each within the scatter of the next); then compound 3.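

Unlike the exchange between the two non-aromatic rings, the move to benzyl shifts the number in this assay beyond the scatter, with a 3.2-fold higher number from compound 2 to compound 3 (0.51 log units; beyond the scatter) and a 5.4-fold higher number from compound 1 to compound 3 (0.73 log units; beyond the scatter) in the direction of weaker inhibition. The group on the carbamate nitrogen can therefore change the result in this small set, even though cyclopentyl and cyclohexyl could not be told apart. Benzyl differs from cyclohexyl both in having an aromatic ring and in its number of heavy atoms, and nothing available here shows why the number rises or which of these differences matters.

The compounds shown cannot separate the aromatic ring from the overall make-up of the benzyl group. A cyclohexylmethyl group on the same nitrogen would keep the non-aromatic ring while matching the heavy-atom count of benzyl, and a phenyl or 2-phenylethyl group would show how the result changes with the aromatic ring attached directly or on a longer chain.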